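From acetyl to methyl in a series that barely moves

The source may hold more compounds than are shown below. What is called first, only, known or untested is meant among the compounds shown, and "the series" means these compounds.

Of the compounds shown here, three that share one core have been measured in an ADME assay on HepG2 cells (Homo sapiens) for cytotoxicity, with a stated time of 72 h; on this read-out lower numbers stand for an effect already at smaller amounts and higher numbers for an effect only at larger amounts of compound. Compound 1 `Cc1cc(NC(=O)Nc2ccc(C(C)(C)C)cc2)c2ccccc2n1` gives 17000 nM. Compound 2 `CSc1ccc(NC(=O)Nc2cc(C)nc3ccccc23)cc1` gives 16000 nM. Compound 3 `CC(=O)c1ccc(NC(=O)Nc2cc(C)nc3ccccc23)cc1` gives 19000 nM, which places it level with the other two, as its gaps to both lie within the usual scatter.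

The next compound is compound 4 `Cc1ccc(NC(=O)Nc2cc(C)nc3ccccc23)cc1`, with methyl in place of acetyl on an aromatic carbon, para to a large group (methyl in place of acetyl on an aromatic carbon).

Three measured steps exchange the group at this same place. Acetyl in place of tert-butyl gave a 1.1-fold higher number from compound 1 to compound 3 (0.05 log units; within the scatter). Acetyl in place of methylsulfanyl gave a 1.2-fold higher number from compound 2 to compound 3 (0.07 log units; within the scatter). Methylsulfanyl in place of tert-butyl gave a 1.1-fold lower number from compound 1 to compound 2 (0.03 log units; within the scatter). All three steps stay within the scatter, so the group at this place has not yet shifted the number in this assay. None of these compounds carries methyl, however, so this expectation is an extension from other groups.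

The expected result is a 1.1-fold lower number from compound 3 to compound 4 (0.05 log units; within the scatter), which means no step beyond the scatter and no clear direction. For compound 4 the estimated value is 17000 nM, with an expected range from 9000 nM to 30000 nM.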

Compound 4, half-maximal effective concentration: > 25000 nM
Compound 4 gave a limit, no number; the forecaster's own chance of this, stated with the estimate: 10%; at least 1.4-fold (0.16 log units) between middle value and limit.
By their numbers in this assay, from the lowest: compounds 2, 1 and 3 (each within the scatter of the next). At a limit, above all of these: compound 4.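

In this assay, compound 4 gives > 25000 nM, which is a limit of the assay and not a number. From the compounds shown here alone, measured against that limit, the change to methyl gives an at least 1.3-fold higher number from compound 3 to compound 4 (0.11 log units; that floor lies within the scatter), and the comparisons with the other two groups give an at least 1.5-fold higher number from compound 2 to compound 4 (0.19 log units; that floor lies within the scatter) and an at least 1.4-fold higher number from compound 1 to compound 4 (0.16 log units; that floor lies within the scatter), so each floor stays within the scatter, while the real size of each step remains unknown and could be larger. This position therefore holds something the earlier compounds did not show: with methyl on this aromatic carbon, the read-out no longer yields a number, unlike with acetyl, methylsulfanyl or tert-butyl, and compound 4 stands alone in that: the limit of > 25000 nM in this assay, at which 1 of the 4 values shown sits.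

Going by these compounds, whether methyl truly separates from those three groups stays open, as a limit offers no exact value to set against theirs. Also open, on these data alone, is how an amine, a carboxylic acid or a longer chain such as propyl would read on this aromatic carbon, and whether any group here can move the number clearly lower.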